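The source may hold more compounds than are shown below. What is called first, only, known or untested is meant among the compounds shown, and "the series" means these compounds.

Compound 1 `CC(C)(C)OC(=O)NCCC[C@@H]1N=C2C[C@@H]3C[C@@H](C3(C)C)[C@]2(C)OC1=O` gives > 1200000 nM in an ADME assay on McCoy cells (Mus musculus) for antiproliferative activity, read by sulforhodamine B assay, with a stated time of 48 h; a higher number here means a weaker inhibitor, a lower number a stronger inhibitor. Compound 2 `C[C@H]1N=C2C[C@H]3C[C@H](C3(C)C)[C@@]2(C)OC1=O` gives > 1800000 nM in this assay. Compound 3 `CC(C)(C)OC(=O)NCCCC[C@@H]1N=C2C[C@@H]3C[C@@H](C3(C)C)[C@]2(C)OC1=O` gives > 800000 nM in this assay.

Each of these three values is a limit of the assay and not a number. For the measured compounds named here, the single step between measured compounds, a step that the two limits leave unreadable from compound 1 to compound 3, therefore cannot be read in size or direction. Going by the values given here, compound 2 stands at its own limit, (the limit of > 1800000 nM in this assay, at which 1 of the 3 values shown sits), with no measured compound that can be placed clearly stronger or weaker than it. Compound 4 `C[C@@H]1N=C2C[C@@H]3C[C@@H](C3(C)C)[C@]2(C)OC1=O` differs from compound 2 in that (the two compounds have the same atoms and bonds and differ only in configuration as drawn: 4 of 4 stereo elements differ (all stereocentres are inverted: mirror images); a stereocentre at a saturated ring carbon is drawn R in compound 2 and S in compound 4; a stereocentre at a saturated ring carbon is drawn R in compound 2 and S in compound 4; a stereocentre at a saturated ring carbon is drawn R in compound 2 and S in compound 4; a stereocentre at a saturated ring carbon is drawn R in compound 2 and S in compound 4). Among the compounds with values here, no measured step bears on a mirror-image change of this kind, and all values shown are limits, so no size or direction of step can be drawn from them. Compound 4 is expected to show a step of a number no higher from compound 2 to compound 4 (the limit leaves the size open), most likely again only a limit. The estimate for compound 4 is 1800000 nM, within a range from 400000 nM to 6000000 nM.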

Compound 4, half-maximal inhibitory concentration: > 2000000 nM
Compound 4: a limit, no number; the forecaster's own chance of this, stated with the estimate: 85%; at least 1.1-fold (0.04 log units) between middle value and limit.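

In this assay compound 2 and compound 4 each give only a limit, and the step between these two mirror images cannot be read. The compounds shown leave open what number any of them would reach, and whether configuration changes it at all.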